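From 4-fluorophenyl to 4-chlorophenyl: one atom changed

This account rests on a few compounds, and the source may have more. Where it says the series, first, only, none or still open, it means among the compounds named here.

compound 1 `Fc1ccc(-c2nn(-c3ccccc3)cc2-c2nc3cc(C(F)(F)F)ccc3[nH]2)cc1`: 3520 nM
compound 2 `O=C(OCc1ccccc1)c1ccc2[nH]c(-c3cn(-c4ccccc4)nc3-c3ccc(F)cc3)nc2c1`: 23600 nM

In a functional assay on HeLa cells (Homo sapiens) for antiproliferative activity, read by MTT assay, with a stated time of 48 h (on this read-out higher numbers stand for weaker inhibition and lower numbers for stronger inhibition), compound 1 gives 3520 nM and holds the lower of the two numbers, which makes it the stronger inhibitor of the pair. Compound 3 `FC(F)(F)c1ccc2[nH]c(-c3cn(-c4ccccc4)nc3-c3ccc(Cl)cc3)nc2c1` has not been measured yet. It keeps the core of compound 1 and differs at one place: chloro in place of fluoro on an aromatic carbon. In words, this is chloro in place of fluoro on an aromatic carbon, para to a large group, so 4-fluorophenyl becomes 4-chlorophenyl.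

Within the data shown here, the only measured step is a 6.7-fold higher number from compound 1 to compound 2 (0.83 log units; beyond the scatter) and it has benzyloxycarbonyl in place of trifluoromethyl on an aromatic carbon. Among the measured compounds shown here, that is a different change at a different place, so no measured pair tests fluoro against chloro. With compound 1 at 3520 nM as the closest reference, no step beyond the scatter is expected in this assay for this small swap. The estimate means a 1.0-fold lower number from compound 1 to compound 3 (0.00 log units; within the scatter) as the expected step. The estimated value for compound 3 is 3500 nM with an expected range of 1400 nM to 9000 nM for most repeat measurements.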

Compound 3, half-maximal inhibitory concentration: 4420 nM
Beside the measured number, compound 3's estimate is 1.3-fold (0.10 log units) below it, within the range that was stated.
By their numbers in this assay, from the lowest: compounds 1 and 3 (each within the scatter of the next); then compound 2.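

In this assay, chloro in place of fluoro on this aromatic carbon gives a 1.3-fold higher number from compound 1 to compound 3 (0.10 log units; within the scatter), so the two halogens cannot be told apart on this read-out. Among these compounds, this is the first reading at the 4-fluorophenyl group, as the earlier step, a 6.7-fold higher number from compound 1 to compound 2 (0.83 log units; beyond the scatter), came from benzyloxycarbonyl in place of trifluoromethyl at a different place and said nothing about this one. For this one carbon and this one swap, a heavier halogen leaves the antiproliferative read-out inside the normal spread of repeated measurements, although no measured property of either compound accounts for that result.

On these data alone, two halogens at one position give only a narrow view of what this carbon accepts, so it remains open whether a larger or very different group, such as an amine, a methoxy group or a carboxylic acid, would also stay within the scatter of compound 1. It is also open whether chloro would behave the same way alongside the benzyloxycarbonyl group of compound 2, since the shown compounds test each change only against the trifluoromethyl and 4-fluorophenyl pairing of compound 1.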